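Dropping the Ring Substituent of Compound 2

The source may report more compounds than this note shows. Statements on the series, on what has been measured and on what is new or still open speak of the compounds shown alone.

Measured so far:
compound 1, `Nc1n/c(=N\CCCCc2ccccc2)nc(N)c2c1ncn2Cc1ccccc1`, 18800 nM
compound 2, `CCCCCCCC/N=c1\nc(N)c2ncn(Cc3ccc(OC)cc3)c2c(N)n1`, 4200 nM

Both numbers come from a functional assay on NCI-H460 cells (Homo sapiens) for antiproliferative activity, read by WST assay, with a stated time of 72 h; on this read-out higher numbers stand for weaker inhibition and lower numbers for stronger inhibition. Going by the values given here, of the two, compound 2 gives the lower number, and the nearest neighbour, compound 1, sits at 18800 nM, a gap beyond the usual scatter; no single-point step links the two, so their values are simply noted side by side.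

Compound 3, `CCCCCCCC/N=c1\nc(N)c2nc[nH]c2c(N)n1`, differs from compound 2 in one place: hydrogen in place of 4-methoxybenzyl on an aromatic nitrogen. Among the compounds with values here, no measured pair shows a change of this kind, so the direction must be guessed. Because compound 2 reaches 4200 nM with the 4-methoxybenzyl in place, its loss is expected to cost potency, and the step of a 3.6-fold higher number from compound 2 to compound 3 (0.55 log units; beyond the scatter) is estimated to be upward and beyond the scatter. Compound 3 is therefore expected to give about 15000 nM, in the range 5000 nM to 60000 nM.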

Compound 3, half-maximal inhibitory concentration: "not active" (no number reported)
Compound 3 has no reported number here; no gap can be computed for the estimate.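

Going by these compounds alone, compound 3 is reported as "not active" in this assay, without a number, so no step from compound 2 to compound 3 can be read. Nothing at hand explains this result. The compounds shown leave open how much the 4-methoxybenzyl contributes to the activity of compound 2.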